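The compounds below may be only part of what the source reports. "The series", "measured", "known", "first", "only" and "open" are said of these compounds alone.

Measured compounds in an ADME assay on MT2 cells (Homo sapiens) for cytotoxicity, read by XTT assay, with a stated time of 4 days; a lower number here means that less compound is tolerated, a higher number that more compound is tolerated:

compound 1 `C=CCc1cc(C)c(Oc2ccc([N+](=O)[O-])c(Nc3ccc(C#N)cc3)n2)c(C)c1`: 39700 nM
compound 3 `C=CCc1cc(C)c(Oc2ccc(N)c(Nc3ccc(C#N)cc3)n2)c(C)c1`: 14000 nM
compound 2 `Cc1cc(/C=C/C#N)cc(C)c1Oc1ccc([N+](=O)[O-])c(Nc2ccc(C#N)cc2)c1`: > 100000 nM; for compound 2 this is a limit of this assay, not a number.

The difference between the core of compound 1 and the core of compound 2 is not broken down here. Within the first core, the step from compound 1 to compound 3 is amino in place of nitro on an aromatic carbon. In this assay it gives a 2.8-fold lower number from compound 1 to compound 3 (0.45 log units; beyond the scatter), so the amino compound is tolerated less well than the nitro compound.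

Compound 4 `Cc1cc(/C=C/C#N)cc(C)c1Oc1ccc(N)c(Nc2ccc(C#N)cc2)c1` is not yet measured in this assay. It differs from compound 2 by amino in place of nitro on an aromatic carbon. Within the data shown here, this is the same kind of change as the one from compound 1 to compound 3, but not the same: there the ring carrying the group was a six-membered aromatic ring with 1 nitrogen and the group sat two atoms from the ring nitrogen, whereas here the ring is of carbon only.

For compound 4 a step of about an at least 2.0-fold lower number from compound 2 to compound 4 (0.30 log units; that floor lies within the scatter) is expected, resting on the measured step of a 2.8-fold lower number from compound 1 to compound 3 (0.45 log units; beyond the scatter) carried over to the second core, with the reservation that compound 2 sits only at the limit of > 100000 nM in this assay, at which 1 of the 3 values shown sits, and the surroundings of the change are not the same word for word. On that basis compound 4 is estimated at 50000 nM, with a range from 15000 nM to 150000 nM, and a fair chance that this assay again returns only a limit.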

Compound 4, half-maximal cytotoxic concentration: 8830 nM
Estimate against measurement, compound 4: 5.7-fold (0.75 log units) above, outside the stated range (below it).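

In this assay, amino in place of nitro on an aromatic carbon again gives a lower number on the second core, an at least 11-fold lower number from compound 2 to compound 4 (1.05 log units; beyond the scatter), so the direction seen on the core of compound 1 carries over to the core of compound 2. The size of the step does not carry over, and the two cores give clearly different results: the same change on two cores in this assay, a 2.8-fold lower number (0.45 log units; beyond the scatter) from compound 1 to compound 3 and an at least 11-fold lower number (1.05 log units; beyond the scatter) from compound 2 to compound 4, at least 3.9-fold (0.60 log units) apart, beyond the scatter of two such steps. Compound 2 stands at a limit of the assay and not at a number, so the step on its core is only a floor, and two pairs do not show which of the differences between the cores goes with the larger step: the limit of > 100000 nM in this assay, at which 1 of the 4 values shown sits.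

Still open, going by these compounds, is how the step behaves on a core that differs from the core of compound 1 in one place only, for instance with the ring nitrogen gone and the rest of the molecule kept. Also open, on these data alone, is whether other groups in the same place, such as a methylamino group, an acetamido group or a carboxylic acid, would follow the amino compounds or the nitro compounds in this assay.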